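Chain extension from compound 3 to compound 4

A few compounds are considered here, and "the series" means these few. Any claim that something is new, unique, unknown or untested is made for them only; others in the source may bear on it.

Compound 3 `CCc1ccc2[nH]c(-c3cccc(OC)c3)c(C3=C(Br)C(=O)NC3=O)c2c1` gives 3.35 in a physicochemical assay for lipophilicity (on this read-out lower numbers stand for lower lipophilicity and higher numbers for higher lipophilicity), the lowest of the three measured values, beyond the scatter from both others. Compound 1 `CCCCc1ccc2[nH]c(-c3ccccc3)c(C3=C(Br)C(=O)NC3=O)c2c1` gives 3.74 and compound 2 `CCCCCCOc1ccc2[nH]c(-c3cccc(OC)c3)c(C3=C(Br)C(=O)NC3=O)c2c1` gives 3.92 in this assay. Compound 4 `CCCCc1ccc2[nH]c(-c3cccc(OC)c3)c(C3=C(Br)C(=O)NC3=O)c2c1` carries ethyl in place of hydrogen on a saturated chain carbon, two bonds along the chain from an aromatic carbon. For the measured compounds named here, the only single-point step measured is a number 0.57 log units lower from compound 2 to compound 3 (beyond the scatter), a longer chain against a shorter one. Compound 1 and compound 3 differ in two places, so their gap is read only as a pair of values. Adding two chain carbons to compound 3 is expected to raise this assay, and the estimated step is a number 0.60 log units higher from compound 3 to compound 4 (beyond the scatter). Compound 4 is accordingly expected at 3.95, with a range from 3.6 to 4.3.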

Compound 4, partition coefficient: 3.81
Compound 4: middle estimate off by 0.14 log units, on the high side; low and high end bracket the measured number.
By their numbers in this assay, from the lowest: compound 3; then compounds 1, 4 and 2 (each within the scatter of the next).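

In this assay, ethyl in place of hydrogen on a saturated chain carbon, two bonds along the chain from an aromatic carbon, reads as a number 0.46 log units higher from compound 3 to compound 4 (beyond the scatter) with the rest of the structure unchanged. Exchanging hexyloxy for butyl gives a number 0.11 log units lower from compound 2 to compound 4 (within the scatter) and methoxy in place of hydrogen on an aromatic carbon gives a number 0.07 log units higher from compound 1 to compound 4 (within the scatter) so neither change separates its pair on this read-out. No supporting data bear on the size of these steps.

Going by these compounds, whether a hexyl chain at this place extends the chain step stays open. So does how an amine on the butyl chain would read.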